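A ring swap on compound 1 in a cell assay

The source may hold more compounds than are shown below. What is called first, only, known or untested is meant among the compounds shown, and "the series" means these compounds.

Compound 1 `COc1ccc(/C=C/C(=O)c2ccc(N)c(-c3ccc(F)cc3)c2)cc1O` gives 940 nM in the assay below
Compound 2 `COc1ccc(/C=C/C(=O)c2cccc(Br)c2)cc1OC` gives 9430 nM in the assay below

Within the data shown here, the assay is a functional assay on A549 cells (Homo sapiens) for cytotoxicity, read by sulforhodamine B assay, with a stated time of 48 h (on this read-out higher numbers stand for weaker inhibition and lower numbers for stronger inhibition), and only these two compounds have numbers so far. Compound 1 (940 nM) has the lower number of the pair, and the gap to compound 2 (9430 nM) lies beyond the usual scatter of repeated measurements.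

The next compound is compound 3 (`Nc1ccc(C(=O)/C=C/c2ccc(O)c(F)c2)cc1-c1ccc(F)cc1`), which keeps the core of compound 1 and changes one part (3-fluoro-4-hydroxyphenyl in place of 3-hydroxy-4-methoxyphenyl on a double-bonded chain carbon bound to a double-bonded chain carbon). It carries 3-fluoro-4-hydroxyphenyl in place of 3-hydroxy-4-methoxyphenyl on a double-bonded chain carbon bound to a double-bonded chain carbon.

Among the measured compounds shown here, no pair of measured compounds shows this change on its own, so the data cannot give its size directly. Compound 2 differs from compound 1 in more than one place and offers only a rough reference. A moderate move toward weaker inhibition in this assay is expected, since compound 1 (940 nM) already holds the lower number. The estimated change is a 3.2-fold higher number from compound 1 to compound 3 (0.50 log units; beyond the scatter) and it could still prove smaller. For compound 3 the estimated value is 3000 nM ( range 800 nM to 11000 nM).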

Compound 3, half-maximal inhibitory concentration: 24500 nM
The estimate for compound 3 lay 8.2-fold (0.91 log units) below the measured number; the measured number lies above the stated range.
By their numbers in this assay, from the lowest: compound 1; then compound 2; then compound 3.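

In this assay, among these compounds, putting 3-fluoro-4-hydroxyphenyl in place of 3-hydroxy-4-methoxyphenyl on a double-bonded chain carbon bound to a double-bonded chain carbon gives a 26-fold higher number from compound 1 to compound 3 (1.42 log units; beyond the scatter) and is the first change at this place that can be read on its own, with the rest of compound 1 held fixed. The step shows that the number in this cell assay depends strongly on what this ring carries, since a single change here moves compound 3 far toward weaker inhibition. Both groups have the same six-membered aromatic ring of carbon and the same count of hydrogen-bond donors, so keeping the ring and that count did not keep the lower number, and no measurement at hand gives a reason for the size of this step.

The swap alters several things at once, as the methoxy group leaves, fluorine enters and the hydroxyl group changes its place on the ring, and the compounds shown cannot say which of these carries the loss. Also open, on these data alone, is how a ring with an amine, such as 3-amino-4-methoxyphenyl, would behave at this place on the same core.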